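The source may report more compounds than this note shows. Statements on the series, on what has been measured and on what is new or still open speak of the compounds shown alone.

As far as these compounds go, the study sets two measured compounds against one that remains untested. Compound 1 `COc1cc(Cl)cc(-c2nn(-c3cccc(NC(=O)c4ccc(Cl)c(Cl)c4)c3)cc2-c2ccncc2)c1` and compound 2 `O=C(Nc1cccc(-n2cc(-c3ccncc3)c(-c3cc(O)cc(Cl)c3)n2)c1)Nc1ccc(Cl)c(C(F)(F)F)c1` share a common core but differ in more than one place, so the two are compared only by what their values show. In a functional assay on Malme-3M cells (Homo sapiens) for inhibition, read by sulforhodamine B assay, with a stated time of 48 h, tested at 10 uM (on this read-out lower numbers stand for a stronger effect and higher numbers for a weaker effect at the one concentration tested), compound 1 gives 96.4%, whereas compound 2 gives -24.9%. Compound 2 thus stands at the lowest of the two numbers, and the gap to compound 1 lies well beyond the usual scatter of the method.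

Compound 3 `O=C(Nc1cccc(-n2cc(-c3ccncc3)c(-c3cc(O)cc(Cl)c3)n2)c1)Nc1ccc(Cl)c(Cl)c1` keeps the whole of compound 2 except for a single change: chloro in place of trifluoromethyl on an aromatic carbon. Among the measured compounds shown here, no measured pair carries this same change, so the data give no direct guide to its size. Because compound 2 already gives -24.9% in this assay, compound 3 is expected to stay close to it, and the step from compound 2 to compound 3 is estimated at a number 12.9 percentage points higher from compound 2 to compound 3 (beyond the scatter), a shift not expected to exceed the scatter. On that basis compound 3 is estimated to give -12%, within a range from -50% to 35%.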

Compound 3, a percentage reported as activity, at one concentration (the size of the read-out at that concentration, not a potency): -35.1%
Estimate against measurement, compound 3: 23.1 percentage points above; the measured number falls inside the stated range.
By their numbers in this assay, from the lowest: compound 3; then compound 2; then compound 1.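

Among the compounds shown here, the exchange of trifluoromethyl for chloro gives the first direct reading at this position: in this assay, turning the 4-chloro-3-(trifluoromethyl)phenyl group into the 3,4-dichlorophenyl group gives a number 10.2 percentage points lower from compound 2 to compound 3 (beyond the scatter). The position, on an aromatic carbon ortho to a chloro group, thus accepts a group of one heavy atom in place of one of four without the read-out returning towards positive numbers, and compound 3 gives -35.1% as the lowest number of the three compounds. The compounds offer no measurement that bears on why the number moves in this direction.

For the compounds shown here, with only this one step at the position, it remains open whether other groups there, such as a nitrile, an amine or a carboxylic acid, would keep the number in the same region or take it back towards that of compound 1. As far as these compounds go, it is equally open whether the exchange of trifluoromethyl for chloro would have a similar effect elsewhere on the shared core, or in cells other than those of this single assay.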